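A few compounds are considered here, and "the series" means these few. Any claim that something is new, unique, unknown or untested is made for them only; others in the source may bear on it.

Working notes on the series. Within the data shown here, the two compounds measured so far share one core and differ only in the group carried on the sulfur. Compound 1 `Cc1cc(N2CC[C@@H](C)[C@@H](N(C)c3ncnc4[nH]ccc34)C2)n2nc(SCc3ccc(Br)cc3)nc2n1` gives 19500 nM in a functional assay on HGC-27 cells (Homo sapiens) for inhibition, read by MTT assay, with a stated time of 72 h; on this read-out lower numbers stand for stronger inhibition and higher numbers for weaker inhibition. Compound 2 `Cc1cc(N2CC[C@@H](C)[C@@H](N(C)c3ncnc4[nH]ccc34)C2)n2nc(SCc3ccc([N+](=O)[O-])cc3)nc2n1` gives 29400 nM in this assay; the step of a 1.5-fold higher number from compound 1 to compound 2 (0.18 log units; within the scatter) leaves compound 2 and compound 1 within the scatter of each other, so neither can be set apart from the other on these numbers. Compound 3 `Cc1cc(N2CC[C@@H](C)[C@@H](N(C)c3ncnc4[nH]ccc34)C2)n2nc(SCCCc3ccccc3)nc2n1` has not yet been measured. Its change from compound 2 is phenethyl in place of 4-nitrophenyl on a saturated chain carbon bound to a sulfur, which cut one bond further out reads 4-nitrobenzyl to 3-phenylpropyl. Among the measured compounds shown here, no measured step speaks to this: the only one, a 1.5-fold higher number from compound 1 to compound 2 (0.18 log units; within the scatter), exchanges one substituent on the aromatic ring for another and stays within the scatter. With the two measured numbers so close, compound 3 is expected to sit near the same level, with an expected step of a 1.2-fold lower number from compound 2 to compound 3 (0.07 log units; within the scatter) and no direction beyond the scatter. Compound 3 is therefore estimated at 25000 nM, between 8000 nM and 75000 nM.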

Compound 3, half-maximal inhibitory concentration: > 100000 nM
Compound 3 gave a limit, no number (the forecaster's own chance of this, stated with the estimate: 15%); middle value at least 4.0-fold (0.60 log units) away from the limit.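

For compound 3 the read-out is a limit of the assay and not a number: the limit of > 100000 nM in this assay, at which 1 of the 3 values shown sits.

Even as a limit it gives the first steps beyond the scatter in the series: an at least 3.4-fold higher number from compound 2 to compound 3 (0.53 log units; beyond the scatter), and an at least 5.1-fold higher number from compound 1 to compound 3 (0.70 log units; beyond the scatter). The group on the sulfur is therefore not indifferent to change in this assay, as the exchange of bromo for nitro on the ring alone could not show, and 3-phenylpropyl reads as weaker than both 4-nitrobenzyl and the bromo analogue.

This change lengthens the chain and removes the ring substituent in one step, so the compounds shown cannot separate the two; a plain benzyl group on the sulfur would do so. Also open, from the compounds shown here alone, is how an amine or a carboxylic acid on that ring would read.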